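Hydroxy in place of chloro on compound 3

The compounds below may be only part of what the source reports. "The series", "measured", "known", "first", "only" and "open" are said of these compounds alone.

compound 1 `O=C1CC(N2C(=O)CSC2=S)C(=O)N1c1ccc(Cl)cc1` gives > 100000 nM as a limit of the assay
compound 2 `O=C1CC(N2C(=O)CSC2=S)C(=O)N1c1ccc(O)cc1` gives 60800 nM as a number
compound 3 `O=C1CC(N2C(=O)/C(=C/C(Cl)=C/c3ccc([N+](=O)[O-])cc3)SC2=S)C(=O)N1c1ccc(Cl)cc1` gives 65900 nM as a number

In a functional assay on SK-OV-3 cells (Homo sapiens) for inhibition, read by MTT assay, with a stated time of 72 h (a higher number here means a weaker inhibitor of growth, a lower number a stronger inhibitor of growth), compound 3 lies within the scatter of compound 2, so no order can be drawn between them. For compound 1 the reading is the limit of > 100000 nM in this assay, at which 1 of the 3 values shown sits, and not a number.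

Compound 4 `O=C1CC(N2C(=O)/C(=C/C(Cl)=C/c3ccc([N+](=O)[O-])cc3)SC2=S)C(=O)N1c1ccc(O)cc1` is not yet measured. It carries hydroxy in place of chloro on an aromatic carbon, the change 4-chlorophenyl to 4-hydroxyphenyl. Within the data shown here, the one measured step with this change is an at least 1.6-fold lower number from compound 1 to compound 2 (0.21 log units; that floor lies within the scatter) and it starts from a limit. A small move to a lower number in this assay is therefore expected, though it may stay within the scatter. The expected step is a 1.9-fold lower number from compound 3 to compound 4 (0.27 log units; within the scatter) on this reading. The estimate for compound 4 is 35000 nM with an expected range of 10000 nM to 85000 nM as the working figure.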

Compound 4, concentration for 50% growth inhibition: > 100000 nM
Compound 4 ended at the assay's limit (the forecaster's own chance of this, stated with the estimate: 10%); at least 2.8-fold (0.45 log units) between middle value and limit.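

In this assay, the change from 4-chlorophenyl to 4-hydroxyphenyl now reads on a second core, with an at least 1.5-fold higher number from compound 3 to compound 4 (0.18 log units; that floor lies within the scatter). Neither step can be placed beyond the scatter, and no shared direction can be read across the two cores: the same change on two cores in this assay, an at least 1.6-fold lower number (0.21 log units; that floor lies within the scatter) from compound 1 to compound 2 and an at least 1.5-fold higher number (0.18 log units; that floor lies within the scatter) from compound 3 to compound 4; the limit leaves it open whether they differ. Compound 4 reads as a limit, not a number, and the limit now recurs in the series: the limit of > 100000 nM in this assay, at which 2 of the 4 values shown sit.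

From the compounds shown here alone, the true size of each step remains open, as each has a limit at one end. Also open, going by these compounds, is how methoxy or an amine at this position would read on the two cores.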